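Tert-butoxycarbonyl on the ring amine: outlook for compound 4

The compounds below may be only part of what the source reports. "The series", "measured", "known", "first", "only" and "open" are said of these compounds alone.

The series is followed in a functional assay on MCF7 cells (Homo sapiens) for inhibition, read by MTT assay, with a stated time of 72 h; on this read-out lower numbers stand for stronger inhibition and higher numbers for weaker inhibition. Compound 2 `S=C(SCc1cn(Cc2ccccc2Cl)nn1)N1CCNCC1` gives 38900 nM, compound 3 `Fc1ccccc1Cn1cc(CSC(=S)N2CCNCC2)nn1` gives 33200 nM, and compound 1 `Cc1ccc(-n2cc(CSC(=S)N3CCN(C(=O)OC(C)(C)C)CC3)nn2)cc1` gives 74200 nM. Compound 2 thus stands second highest of the three, with compound 3 nearest and compound 1 furthest, both within the scatter. Within the data shown here, the only single-place step, a 1.2-fold lower number from compound 2 to compound 3 (0.07 log units; within the scatter), concerns the halogen and does not touch the ring amine. Compound 4 `CC(C)(C)OC(=O)N1CCN(C(=S)SCc2cn(Cc3ccccc3Cl)nn2)CC1` differs from compound 2 by tert-butoxycarbonyl in place of hydrogen on an amine nitrogen in a ring. Among the measured compounds shown here, no measured step covers this change; compound 1 also carries tert-butoxycarbonyl but differs from compound 2 in two places, so only the two values can be set side by side, leaning toward a higher number. Compound 4 is expected at 65000 nM, within 28000 nM to 150000 nM, the expected step being a 1.7-fold higher number from compound 2 to compound 4 (0.22 log units; within the scatter).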

Compound 4, half-maximal inhibitory concentration: 6090 nM
The estimate for compound 4 lay 11-fold (1.03 log units) above the measured number; measured number outside the range, below it.
By their numbers in this assay, from the lowest: compound 4; then compounds 3, 2 and 1 (each within the scatter of the next, the first and the last beyond it).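

Tert-butoxycarbonyl in place of hydrogen on the amine nitrogen in the ring gives a 6.4-fold lower number from compound 2 to compound 4 (0.81 log units; beyond the scatter) in this assay and is the first step in the series beyond the scatter. With tert-butoxycarbonyl on both compounds, the group on the aromatic nitrogen also matters: 2-chlorobenzyl in place of 4-methylphenyl gives a 12-fold lower number from compound 1 to compound 4 (1.09 log units; beyond the scatter) as the listed step. No measurement at hand accounts for either step.

On these data alone, whether the lower number requires tert-butoxycarbonyl itself remains open; acetyl or methyl on the same nitrogen would test this. As far as these compounds go, whether it also holds with 2-fluorobenzyl on the aromatic nitrogen remains open too.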